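Swapping an Amine Chain for an Alcohol Chain

A few compounds are considered here, and "the series" means these few. Any claim that something is new, unique, unknown or untested is made for them only; others in the source may bear on it.

Of the compounds shown here, two have so far been measured in an ADME assay on HEp-2 cells (Homo sapiens) for cytotoxicity, read by CCK-8 assay, with a stated time of 5 days; a lower number here means that less compound is tolerated, a higher number that more compound is tolerated. Compound 1 `CC(O)CNc1cc(N2CCc3ccccc3C2)nc2ccccc12` gives 89000 nM. Compound 2 `Cc1ccc2nc(N3CCCc4ccc(F)cc4C3)cc(NCC(C)N)c2c1` gives 86000 nM. Compound 2 holds the lower of the two numbers, but the gap to compound 1 lies within the scatter of repeated measurements, so the two readings cannot be told apart in this assay. Among the measured compounds shown here, no pair of compounds differing in a single place has been measured yet, so no measured step is available to lean on.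

Compound 3 `Cc1ccc2nc(N3CCCc4ccc(F)cc4C3)cc(NCCO)c2c1` has not yet been measured in this assay. It differs from compound 2 in one place: hydroxymethyl in place of 1-aminoethyl on a saturated chain carbon bound to a nitrogen on an aromatic ring. Both the group that leaves and the group that enters carry one hydrogen-bond donor and one hydrogen-bond acceptor, and neither carries a net charge.

For the measured compounds named here, with no measured step to guide the expectation, this change is expected to produce a step of a 1.2-fold higher number from compound 2 to compound 3 (0.07 log units; within the scatter) in this assay, which does not go beyond the scatter. Compound 3 is therefore expected to give 100000 nM in this assay, within a range from 40000 nM to 250000 nM.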

Compound 3, half-maximal cytotoxic concentration: > 100000 nM
Compound 3: a limit, no number (the forecaster's own chance of this, stated with the estimate: 15%); the middle value sits exactly at the limit.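

In this assay compound 3 gives > 100000 nM, which is a limit of the assay and not a number. This provides the first measured change in one place among the compounds shown: putting hydroxymethyl in place of 1-aminoethyl on a saturated chain carbon bound to a nitrogen on an aromatic ring gives an at least 1.1-fold higher number from compound 2 to compound 3 (0.06 log units; that floor lies within the scatter). The nitrogen of the 1-aminoethyl group is thus not required for a reading this high on this core, while the true size of the step stays unknown because the value of compound 3 ends at the limit of the assay: the limit of > 100000 nM in this assay, at which 1 of the 3 values shown sits.

The compounds shown leave open whether a different group at this place, such as a carboxylic acid or a longer chain ending in an amine, would give a lower number in this assay. They also leave open whether the same change would give a similar result on a different core, such as the core of compound 1.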